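From benzyloxy to trifluoromethoxy on a shared core

The source may hold more compounds than are shown below. What is called first, only, known or untested is meant among the compounds shown, and "the series" means these compounds.

In a physicochemical assay for solubility, read by HPLC, measured as kinetic solubility (on this read-out lower numbers stand for lower solubility and higher numbers for higher solubility), compound 1 `O=[N+]([O-])c1cn2c(n1)[S+]([O-])CC(OCc1ccc(OCc3ccccc3)cc1)C2` gives 5.4 ug/mL as its reading. In this assay compound 2 `O=[N+]([O-])c1cn2c(n1)S(=O)(=O)CC(OCc1ccc(OC(F)(F)F)cc1)C2` gives 10 ug/mL and so lies within the usual scatter of compound 1. Compound 3 `CC1(COCc2ccc(OCc3ccccc3)cc2)Cn2cc([N+](=O)[O-])nc2[S+]1[O-]` gives 1.3 ug/mL and lies lower than compound 1 by more than the scatter.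

Compound 4 `O=[N+]([O-])c1cn2c(n1)[S+]([O-])CC(OCc1ccc(OC(F)(F)F)cc1)C2` has not yet been measured. It differs from compound 1 in one place, on an oxygen on an aromatic ring, where trifluoromethyl stands in place of benzyl trifluoromethyl in place of benzyl on an oxygen on an aromatic ring and benzyloxy thus becomes trifluoromethoxy.

Within the data shown here, no two measured compounds differ in just one place, so the data hold no direct measure of this change. Among the measured compounds shown here, the only measured compound with trifluoromethoxy is compound 2 at 10 ug/mL and that value is within the scatter of compound 1, which makes the case for a rise a weak one. A modest upward step in this assay is nevertheless expected, estimated as a 2.8-fold higher number from compound 1 to compound 4 (0.44 log units; beyond the scatter) and possibly no larger than the scatter. For compound 4 the expected value is 15 ug/mL with an estimated range from 5 ug/mL to 45 ug/mL as its likely span.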

Compound 4, solubility: 39 ug/mL
Compound 4: the middle estimate sits 2.6-fold (0.41 log units) below what was measured, within the range that was stated.
By their numbers in this assay, from the lowest: compound 3; then compounds 1 and 2 (each within the scatter of the next); then compound 4.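

Trifluoromethyl in place of benzyl on an oxygen on an aromatic ring, with the rest of compound 1 unchanged, now has a direct measure: in this assay the change gives a 7.2-fold higher number from compound 1 to compound 4 (0.86 log units; beyond the scatter). Before this pair, no two measured compounds differed in just one place, so this reading is the first to tie a step beyond the scatter to this position alone, and in that step a group with a six-membered aromatic ring of carbon only leaves and a group with no ring enters. No measurement shown here offers a reason for the step.

The step rests on a single pair, so the compounds shown cannot separate the loss of the aromatic ring from the arrival of fluorine, nor show whether the same change gives a similar step on other versions of the shared core. A plain methyl on the same oxygen, with neither ring nor fluorine, and a fluorobenzyl, with both, would be the groups to set beside compound 1 and compound 4.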